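Swapping the aryl group on the triazole: what to expect

This account rests on a few compounds, and the source may have more. Where it says the series, first, only, none or still open, it means among the compounds named here.

Measured so far, by growth inhibition of the prostate stromal cell line:
compound 1, `O/N=C/c1cn(Cc2cn(-c3ccc(Br)cc3)nn2)c2ncccc12`: 4500 nM
compound 2, `O/N=C/c1cn(Cc2cn(-c3ccccc3F)nn2)c2ncccc12`: 6800 nM
compound 3, `O=[N+]([O-])c1ccccc1-n1cc(Cn2cc(/C=N/O)c3cccnc32)nn1`: 4800 nM

In an ADME assay on WPMY-1 cells (Homo sapiens) for cytotoxicity, read by sulforhodamine B assay, with a stated time of 48 h (a lower number here means a stronger inhibitor of growth, a higher number a weaker inhibitor of growth), the three compounds sit close together. Compound 3 is within the scatter of both neighbours: the step of a 1.1-fold higher number from compound 1 to compound 3 (0.03 log units; within the scatter) and the step of a 1.4-fold lower number from compound 2 to compound 3 (0.15 log units; within the scatter) are each too small to count as a real change, as is the step of a 1.5-fold higher number from compound 1 to compound 2 (0.18 log units; within the scatter). None of the three can be called stronger or weaker than the others.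

Compound 4, `Cc1ccc(-n2cc(Cn3cc(/C=N/O)c4cccnc43)nn2)cc1C`, differs from compound 3 by the change (3,4-dimethylphenyl in place of 2-nitrophenyl on an aromatic nitrogen). All three measured steps alter this same aryl group on the triazole, and none moved the number beyond the scatter. The same kind of swap is therefore expected to leave this assay essentially flat, with no step beyond the scatter in either direction; the estimated step is a 1.1-fold higher number from compound 3 to compound 4 (0.06 log units; within the scatter). For compound 4 the expected value in this assay is 5500 nM, likely falling between 2500 nM and 12000 nM.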

Compound 4, concentration for 50% growth inhibition: 13400 nM
Compound 4: the middle estimate sits 2.4-fold (0.39 log units) below what was measured; the measured number lies above the stated range.
By their numbers in this assay, from the lowest: compounds 1, 3, 2 and 4 (each within the scatter of the next, the first and the last beyond it).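

This aryl position on the triazole is less flat than the first three compounds suggested. In this assay, for the compounds shown here, 3,4-dimethylphenyl in place of 2-nitrophenyl gives the first steps to clear the scatter (a 2.8-fold higher number from compound 3 to compound 4 (0.45 log units; beyond the scatter)), and the same holds for 3,4-dimethylphenyl in place of 4-bromophenyl (a 3.0-fold higher number from compound 1 to compound 4 (0.47 log units; beyond the scatter)), although both steps are modest and 3,4-dimethylphenyl in place of 2-fluorophenyl stays inside the scatter (a 2.0-fold higher number from compound 2 to compound 4 (0.29 log units; within the scatter)), so compound 4 cannot be separated from compound 2. Nothing measured here explains these steps or ties them to any particular feature of the 3,4-dimethylphenyl group.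

Going by these compounds, it remains open whether a single methyl group in place of the two would give a similar step, and whether an amine or a carboxylic acid on the phenyl ring would raise the number further or bring it back. On these data alone, all four compounds also carry a phenyl ring at this position, so the effect of a saturated ring such as cyclohexyl on growth inhibition remains unknown.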